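Swapping Acid and Amide on the Branched Chain

A few compounds are considered here, and "the series" means these few. Any claim that something is new, unique, unknown or untested is made for them only; others in the source may bear on it.

Of the compounds shown here, three sharing one core have been tested in a functional assay on ileum (Cavia porcellus) for antagonist activity at cysteinyl leukotriene receptor (Homo sapiens); a lower number here means a stronger inhibitor, a higher number a weaker inhibitor. Compound 1 `CC(C)(CC(=O)Nc1cccc(OCc2ccc3ccc(F)cc3n2)c1)C(=O)O` gives 1.4 nM, compound 2 `CCCC(CCC)(CC(=O)Nc1cccc(OCc2ccc3ccc(F)cc3n2)c1)C(=O)O` gives 2 nM, and compound 3 `O=C(CC1(C(=O)O)CCCC1)Nc1cccc(OCc2ccc3ccc(F)cc3n2)c1` gives 10 nM, the highest of the three numbers. The steps of a 7.1-fold higher number from compound 1 to compound 3 (0.85 log units; beyond the scatter) and a 5.0-fold higher number from compound 2 to compound 3 (0.70 log units; beyond the scatter) show that both open-chain branches gave lower numbers than the ring. Compound 4 `CCC(CC)(CC(=O)O)C(=O)Nc1cccc(OCc2ccc3ccc(F)cc3n2)c1` differs from compound 3 by 1-(carboxymethyl)-1-ethylpropyl in place of (1-carboxycyclopentyl)methyl on a carbonyl carbon. Among the compounds with values here, this change opens the ring, as in compounds 1 and 2, but also swaps the places of the acid and the amide, a move that no measured pair covers, so the outcome is uncertain. Compound 4 is therefore expected to sit near 5 nM, within a range from 1.5 nM to 25 nM. The step expected is a 2.0-fold lower number from compound 3 to compound 4 (0.30 log units; within the scatter).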

Compound 4, half-maximal inhibitory concentration: 140 nM
For compound 4 the middle estimate is 28-fold (1.45 log units) below the measured one, outside the stated range (above it).
By their numbers in this assay, from the lowest: compounds 1 and 2 (each within the scatter of the next); then compound 3; then compound 4.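

With 1-(carboxymethyl)-1-ethylpropyl on the carbonyl carbon, the steps are far larger than any seen among the earlier branches (a 14-fold higher number from compound 3 to compound 4 (1.15 log units; beyond the scatter)) and (a 70-fold higher number from compound 2 to compound 4 (1.85 log units; beyond the scatter)) and (a 100-fold higher number from compound 1 to compound 4 (2.00 log units; beyond the scatter)). The order of acid and amide along this chain therefore appears to count for more than the choice among the earlier branches, although the ring opening and the changed branch come with it in this single step. No measurement here explains the rise. A 2-carboxy-2-ethylbutyl group on the carbonyl carbon would show how much of the rise belongs to the swap alone. As far as these compounds go, whether a longer chain between the acid and the branched carbon would restore the lower numbers remains open.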